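The compounds below may be only part of what the source reports. "The series", "measured", "known", "first", "only" and "open" are said of these compounds alone.

Going by the values given here, in an ADME assay on microsomes (Mus musculus) for metabolic stability (a lower number here means slower removal, a higher number faster removal of the compound), compound 1 (`CNC(=O)[C@@H]1CCCN1S(=O)(=O)c1ccc(Cl)c(COc2cccc3c(-n4ccnc4)cc(C)nc23)c1Cl`) gives 267 mL/min/kg, the lowest of the two numbers so far. Among the compounds with values here, the only other measured compound, compound 2 (`Cc1cc(C(F)(F)F)c2cccc(OCc3c(Cl)ccc(S(=O)(=O)N4CCC(CCO)CC4)c3Cl)c2n1`), gives 1080 mL/min/kg, a gap beyond the scatter, but the two differ in more than one place. Compound 3 (`CNC(=O)[C@@H]1CCCN1S(=O)(=O)c1ccc(Cl)c(COc2cccc3c(OCc4ccccc4)cc(C)nc23)c1Cl`) keeps the core of compound 1 and changes one group: benzyloxy in place of 1H-imidazol-1-yl on an aromatic carbon, opposite the ring nitrogen (benzyloxy in place of 1H-imidazol-1-yl on an aromatic carbon). Within the data shown here, no measured step bears on this change. Faster removal in this assay is nevertheless expected, a step beyond the scatter, since compound 1 at 267 mL/min/kg sits at the low end and compound 2 at 1080 mL/min/kg shows how much higher the number can go. The expected change is a 2.2-fold higher number from compound 1 to compound 3 (0.35 log units; beyond the scatter). For compound 3 the estimated clearance is 600 mL/min/kg, with an expected range of 280 mL/min/kg to 1200 mL/min/kg.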

Compound 3, clearance: 1820 mL/min/kg
Estimate against measurement, compound 3: 3.0-fold (0.48 log units) below; measured number above the stated range.
By their numbers in this assay, from the lowest: compound 1; then compounds 2 and 3 (each within the scatter of the next).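

In this assay, putting benzyloxy in place of 1H-imidazol-1-yl on the aromatic carbon opposite the ring nitrogen gives a 6.8-fold higher number from compound 1 to compound 3 (0.83 log units; beyond the scatter). Going by these compounds alone, this is the first step here with only one place changed, and it shows that the group at this position alone can move the number beyond the scatter while the rest of the core of compound 1 stays the same. Nothing measured here explains the step.

One pair cannot separate the parts of the change, since a five-membered aromatic ring with 2 hetero atoms leaves and an oxygen-linked six-membered aromatic ring of carbon only enters. As far as these compounds go, it remains open where a methoxy group, a plain phenyl ring or an amine on this carbon would fall, and whether the step would recur with the sulfonyl-linked piperidine of compound 2.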